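Adding a methyl group to the nitro-bearing ring of compound 3

The compounds below may be only part of what the source reports. "The series", "measured", "known", "first", "only" and "open" are said of these compounds alone.

Three compounds share one core and differ only in the aromatic group on the amide-type nitrogen. In a functional assay on A549 cells (Homo sapiens) for cytotoxicity, read by MTT assay (on this read-out lower numbers stand for stronger inhibition and higher numbers for weaker inhibition), compound 1 `CCn1cc(C(=O)Nc2ccccc2O)c(=O)c2cc(F)c(N3CCNC(C)C3)c(F)c21` gives 24800 nM, compound 2 `CCn1cc(C(=O)Nc2ccc(Cl)cn2)c(=O)c2cc(F)c(N3CCNC(C)C3)c(F)c21` gives 3300 nM, and compound 3 `CCn1cc(C(=O)Nc2cccc([N+](=O)[O-])c2)c(=O)c2cc(F)c(N3CCNC(C)C3)c(F)c21` gives 3240 nM. Compound 3 has the lowest number of the three, but compound 2 lies within the scatter of it, so the two cannot be ranked; compound 1 is clearly apart, with a 7.7-fold lower number from compound 1 to compound 3 (0.88 log units; beyond the scatter) and a 7.5-fold lower number from compound 1 to compound 2 (0.88 log units; beyond the scatter), while a 1.0-fold lower number from compound 2 to compound 3 (0.01 log units; within the scatter).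

Compound 4 `CCn1cc(C(=O)Nc2ccc(C)c([N+](=O)[O-])c2)c(=O)c2cc(F)c(N3CCNC(C)C3)c(F)c21` keeps the 3-nitrophenyl group of compound 3 and adds one change: methyl in place of hydrogen on an aromatic carbon. Among the compounds with values here, no measured step adds a single small group to an otherwise fixed aromatic ring; the measured steps all exchange the whole aromatic group, and even those were at most modest. Since compounds 2 and 3 sit together despite very different groups, one added methyl is not expected to move this assay beyond the scatter, so a 1.1-fold lower number from compound 3 to compound 4 (0.03 log units; within the scatter) is the estimated step. Compound 4 is therefore expected to give about 3000 nM, between 1000 nM and 9000 nM.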

Compound 4, half-maximal inhibitory concentration: 3700 nM
Compound 4: the middle estimate sits 1.2-fold (0.09 log units) below what was measured; the measured number falls inside the stated range.
By their numbers in this assay, from the lowest: compounds 3, 2 and 4 (each within the scatter of the next); then compound 1.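

Within the data shown here, this is the first step that adds a single small group to an otherwise fixed aromatic ring: in this assay, methyl in place of hydrogen, ortho to a nitro group and para to a large group, gives a 1.1-fold higher number from compound 3 to compound 4 (0.06 log units; within the scatter), so this addition at this position leaves the number unchanged within the scatter. The 4-methyl-3-nitrophenyl group also cannot be separated from the 5-chloropyridin-2-yl group, with a 1.1-fold higher number from compound 2 to compound 4 (0.05 log units; within the scatter), while the gap from the 2-hydroxyphenyl group remains, with a 6.7-fold lower number from compound 1 to compound 4 (0.83 log units; beyond the scatter). No accompanying measurement explains this flat result.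

From the compounds shown here alone, whether a larger group on the same carbon, such as a longer chain or a carboxylic acid, would also leave the number in place remains open. Open too, going by these compounds, is whether the nitro group matters at all, which an amine in its place would test.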